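The compounds below may be only part of what the source reports. "The series", "measured", "known", "first", "only" and "open" are said of these compounds alone.

Compound 1, whose structure is `CN(C)[C@H]1CC[C@@H](C(=O)Nc2cc3cc[nH]c(=O)c3cc2Cl)CC1`, has no result in a functional assay (aorta) with Rattus norvegicus as the target; a lower number here means that less compound is needed, a higher number that more compound is needed for the effect: for compound 1 the entry reads "not determined" (no result reported), so there is no number for it to start from. Two related compounds share its core. Compound 2, with the structure `CC(C)[C@@H](N)C(=O)Nc1cc2cc[nH]c(=O)c2cc1Cl`, likewise has no result in this assay: for compound 2 the entry reads "not determined" (no result reported). Within the data shown here, compound 3, drawn as `CC(C)[C@H](N)C(=O)Nc1cc2cc[nH]c(=O)c2cc1Cl`, is the only one with a number: in this assay compound 3 gives 500 nM. Among the measured compounds shown here, compounds 2 and 3 are a pair in which (the fact that compounds 2 and 3 differ only in the configuration as drawn), and only compound 3 carries a value, so that pair gives no measured step either.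

The compound still to be measured is compound 4, with the structure `N[C@H]1CC[C@@H](C(=O)Nc2cc3cc[nH]c(=O)c3cc2Cl)CC1`. It differs from compound 1 in one place: amino in place of dimethylamino on a saturated ring carbon. For the measured compounds named here, since compound 1 itself has no number, no step between measured compounds exists for this change, and the size of the step from compound 1 to compound 4 cannot be set from these data; a step within the usual scatter, in either direction, is the plain expectation. Going by the values given here, on the single number available, that of compound 3, compound 4 is expected to reach about 500 nM in this assay, with a range from 100 nM to 3000 nM.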

Compound 4, half-maximal effective concentration: 180 nM
The estimate for compound 4 lay 2.8-fold (0.44 log units) above the measured number; low and high end bracket the measured number.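

Compound 4 shows that the shared core still gives a measurable effect in this assay when the carbonyl carbon carries 4-aminocyclohexyl, with its six-membered non-aromatic ring of carbon only, instead of 1-amino-2-methylpropyl. Replacing one group with the other gives a 2.8-fold lower number from compound 3 to compound 4 (0.44 log units; beyond the scatter), so less compound is needed for the effect with the ring-bearing group. Nothing measured here accounts for this step.

On these data alone, the steps that involve compound 1 or compound 2 cannot be read, so the effect of swapping dimethylamino for amino on the ring and the effect of the configuration as drawn both remain unknown. As far as these compounds go, it also remains open how a methylamino group, a hydroxyl group or a carboxylic acid in place of the amino group on the ring would compare.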